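Swapping Chloro for Fluoro in a Fast-Clearing Amide Series

The source may report more compounds than this note shows. Statements on the series, on what has been measured and on what is new or still open speak of the compounds shown alone.

In an ADME assay on the whole organism (Rattus norvegicus, strain Sprague-Dawley) for pharmacokinetics, read by LC-MS, with a stated time of 24 h, at a dose of 1 mg/kg by the intravenous route (on this read-out lower numbers stand for slow clearance and higher numbers for fast clearance), compound 2 `CN1CCC(=C(F)c2cccc(NC(=O)c3ccc(Cl)cc3)n2)CC1` gives 180 mL/min/kg, and compound 1 `CN1CCC(=C(F)c2cccc(NC(=O)c3ccc(Cl)cc3F)n2)CC1` gives 178 mL/min/kg. For the measured compounds named here, the single measured step, a 1.0-fold higher number from compound 1 to compound 2 (0.00 log units; within the scatter), stayed within the scatter, so compound 2 sits alongside compound 1 rather than apart from it. Compound 3 `CN1CCC(=C(F)c2cccc(NC(=O)c3ccc(F)cc3)n2)CC1` is the next compound; its change from compound 2 is fluoro in place of chloro on an aromatic carbon. Going by the values given here, no measured step tests a halogen swap at this place, and the one step that exists left the number unchanged, so compound 3 is expected to show no shift beyond the scatter: a 1.0-fold lower number from compound 2 to compound 3 (0.01 log units; within the scatter). Compound 3 is therefore estimated at 175 mL/min/kg, within 110 mL/min/kg to 280 mL/min/kg.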

Compound 3, clearance: 156 mL/min/kg
For compound 3 the middle estimate is 1.1-fold (0.05 log units) above the measured one; low and high end bracket the measured number.
By their numbers in this assay, from the lowest: compounds 3, 1 and 2 (each within the scatter of the next).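

Replacing 4-chlorophenyl with 4-fluorophenyl gives a 1.2-fold lower number from compound 2 to compound 3 (0.06 log units; within the scatter) in this assay, so this halogen swap, para to a large group, does not separate the two compounds. The larger replacement of 4-chloro-2-fluorophenyl by 4-fluorophenyl gives a 1.1-fold lower number from compound 1 to compound 3 (0.06 log units; within the scatter) and likewise leaves the compounds together. No supporting measurement explains these results. Still open, as far as these compounds go, is whether an amine or a carboxylic acid at this place, instead of a halogen, would move the clearance number beyond the scatter.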